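This account rests on a few compounds, and the source may have more. Where it says the series, first, only, none or still open, it means among the compounds named here.

Three measured compounds share a core. In a physicochemical assay for acid dissociation, compound 1 `COc1ccc(-c2ccc3c(NCCCNCc4cccc(OC)c4O)ccnc3c2)cc1` gives 9.47, compound 2 `FC(F)(F)c1ccc(-c2ccc3c(NCCCNCc4ccco4)ccnc3c2)cc1` gives 9.47, and compound 3 `COc1ccc(F)cc1CNCCCNc1ccnc2cc(C3CCCCC3)ccc12` gives 9.47. Compound 2 stands level with compounds 1 and 3 at the digits shown; its nearest neighbour is compound 1 and its furthest compound 3, with no change at those digits in either direction, both within the scatter. Compound 4 `COc1cccc(Oc2ccc3c(NCCCNCc4ccco4)ccnc3c2)c1` has not yet been measured in this assay. It differs from compound 2 in one place: 3-methoxyphenoxy in place of 4-(trifluoromethyl)phenyl on an aromatic carbon. Since three compounds bearing different groups all give the same reading, no step beyond the scatter is expected from compound 2 to compound 4, no change at the digits printed from compound 2 to compound 4 (within the scatter). Compound 4 is therefore estimated at 9.47, in the range 9.2 to 9.75.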

Compound 4, acid dissociation constant: 9.28
Compound 4: middle estimate off by 0.19 log units, on the high side; the measured number falls inside the stated range.
By their numbers in this assay, from the lowest: compounds 4, 1, 2 and 3 (each within the scatter of the next).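

In this assay, 3-methoxyphenoxy in place of 4-(trifluoromethyl)phenyl on this aromatic carbon gives a number 0.19 log units lower from compound 2 to compound 4 (within the scatter). Within the data shown here, this is the first step that can be read at this position, and it stays within the scatter even though the entering group has 2 hydrogen-bond acceptors and the leaving group has 0. Nothing available accounts for the direction of this step. The compounds shown leave open whether an amine or a carboxylic acid on this aromatic carbon would move the reading beyond the scatter.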